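A few compounds are considered here, and "the series" means these few. Any claim that something is new, unique, unknown or untested is made for them only; others in the source may bear on it.

Compound 1 `O=C(Nc1cccc(Cl)c1)Nc1cc2ncncc2cc1OCc1ccccc1Cl` gives 2800 nM
Compound 2 `O=C(Nc1cc2ncncc2cc1OCc1ccc(Cl)cc1)Nc1cccc2ccccc12` gives 7700 nM
Compound 3 `O=C(Nc1ccccc1F)Nc1cc2ncncc2cc1OCc1ccccc1` gives 5900 nM
Compound 4 `O=C(Nc1cc2ncncc2cc1OCc1ccc(F)cc1)Nc1cccc2ccccc12` has not yet been measured

In a functional assay on GBM3 cells (Homo sapiens) for antiproliferative activity, read by WST assay, with a stated time of 72 h (a lower number here means a stronger inhibitor, a higher number a weaker inhibitor), compound 2 (7700 nM) lies within the scatter of compound 3 (5900 nM) and is clearly weaker than compound 1 (2800 nM). Compound 4 changes one place of compound 2 (fluoro in place of chloro on an aromatic carbon): the place is para to a large group, so 4-chlorobenzyl becomes 4-fluorobenzyl. Among the measured compounds shown here, no measured pair shows this swap alone, so no step beyond the scatter is expected in this assay in either direction. The estimated move is small (a 1.2-fold lower number from compound 2 to compound 4 (0.07 log units; within the scatter)). The estimate for compound 4 is 6500 nM (expected range 3000 nM to 14000 nM).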

Compound 4, half-maximal inhibitory concentration: 8300 nM
Compound 4: middle estimate off by 1.3-fold (0.11 log units), on the low side, within the range that was stated.
By their numbers in this assay, from the lowest: compound 1; then compounds 3, 2 and 4 (each within the scatter of the next).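

In this assay, fluoro in place of chloro at this place gives a 1.1-fold higher number from compound 2 to compound 4 (0.03 log units; within the scatter). With the rest of the molecule unchanged, 4-chlorobenzyl and 4-fluorobenzyl therefore cannot be told apart in this test. No measurement available here offers an explanation for this result.

Still open, as far as these compounds go, is whether a methoxy group or an amine at the same place would shift the number beyond the scatter. It is also unknown whether this swap would look the same with the other aryl groups on the core.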